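The compounds below may be only part of what the source reports. "The series", "measured", "known", "first", "only" and "open" are said of these compounds alone.

Measured compounds:

Compound 1 `Cn1ncc2cc(-c3cnc4[nH]ccc4c3N3CCC4(CCNC4=O)CC3)ccc21` — 7 nM
Compound 2 `O=C1NCCC12CCN(c1c(-c3ccn4ccnc4c3)cnc3[nH]ccc13)CC2` — 68 nM

The two measured compounds share a core and differ only in the aromatic group attached to it. In an assay on cells for binding affinity to Cyclin-C/Cyclin-dependent kinase 19 (Homo sapiens), read by LanthaScreen (a higher number here means a weaker inhibitor, a lower number a stronger inhibitor), compound 1 gives 7 nM and compound 2 gives 68 nM. Compound 1 therefore holds the lowest number of the two; the step of a 9.7-fold higher number from compound 1 to compound 2 (0.99 log units; beyond the scatter) is modest in size but lies beyond the scatter.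

Compound 3 `Cn1ncc2cc(-c3cnc4[nH]cc(Cl)c4c3N3CCC4(CCNC4=O)CC3)ccc21` keeps the aromatic group of compound 1 and alters the core instead: chloro in place of hydrogen on an aromatic carbon. Among the compounds with values here, the one measured step concerns a different position, the group on the aromatic carbon of the six-membered ring, and so does not bear directly on a change at the five-membered ring. Within the data shown here, no measured pair shows what a halogen at this position does.

With nothing to point either way, the expectation is a step of a 1.1-fold higher number from compound 1 to compound 3 (0.06 log units; within the scatter), within the scatter. Compound 3 is therefore estimated at 8 nM in this assay, with a range from 3 nM to 25 nM.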

Compound 3, half-maximal inhibitory concentration: 10 nM
Compound 3: the middle estimate sits 1.3-fold (0.10 log units) below what was measured, within the range that was stated.
By their numbers in this assay, from the lowest: compounds 1 and 3 (each within the scatter of the next); then compound 2.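

In this assay, chloro in place of hydrogen on an aromatic carbon of the five-membered aromatic ring, two ring bonds from the ring nitrogen, gives a 1.4-fold higher number from compound 1 to compound 3 (0.15 log units; within the scatter), so compound 1 and compound 3 cannot be told apart in this measurement. Within the data shown here, this is the first reading at this position, and it shows that a single chlorine can stand here on the core of compound 1 with no step beyond the scatter, unlike the exchange of the aromatic group, which gave a 9.7-fold higher number from compound 1 to compound 2 (0.99 log units; beyond the scatter). No measurement available here offers an explanation of this result.

The compounds shown leave open whether other groups on this carbon, such as fluoro, methyl, a nitrile or an amine, would also stay within the scatter of compound 1, so this single chloro result cannot yet be read as a tolerance of the position in general. They also leave open whether chloro at this position would give a similar reading alongside the aromatic group of compound 2, since the two changes appear together in no compound shown.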